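The source may hold more compounds than are shown below. What is called first, only, known or untested is meant among the compounds shown, and "the series" means these compounds.

Measured in a functional assay on HCT-116 cells (Homo sapiens) for inhibition, read by colorimetric assay, with a stated time of 3 days; on this read-out higher numbers stand for weaker inhibition and lower numbers for stronger inhibition:
- Compound 1 `C/C(=N\O)C(=O)NCCCCCC(=O)Nc1ccccc1`: > 100000 nM, a limit.
- Compound 2 `O=C(CCCCCCNC(=O)c1cc(=O)c(O)co1)Nc1ccccc1`: > 100000 nM, a limit.
- Compound 3 `NC(=O)C(=O)NCCCCCC(=O)Nc1ccccc1`: > 100000 nM, a limit.

Going by the values given here, compound 3 thus stands only at a limit, as do the other two compounds, and the series so far shows (the limit of > 100000 nM in this assay, at which 3 of the 3 values shown sit).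

Compound 4 `CC(=O)C(=O)NCCCCCCC(=O)Nc1ccccc1` carries ((acetylcarbonyl)amino)methyl in place of (carbamoylcarbonyl)amino on a saturated chain carbon, five bonds along the chain from a carbonyl carbon. Among the compounds with values here, the only measured step that bears on this change is a step that the two limits leave unreadable from compound 1 to compound 3, and it has no readable size. No step beyond the scatter is therefore expected in this assay, in either direction, and another limit is the likeliest outcome. The estimated step is a number no higher from compound 3 to compound 4 (the limit leaves the size open). The expected value for compound 4 is 100000 nM, with an estimated range of 30000 nM to 200000 nM.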

Compound 4, half-maximal inhibitory concentration: > 100000 nM
Compound 4 gave a limit, no number (the forecaster's own chance of this, stated with the estimate: 80%); the middle value lies on the limit itself.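

Compound 4, like compound 1, compound 2 and compound 3, gives only a limit, so no step among them can be read: the limit of > 100000 nM in this assay, at which 4 of the 4 values shown sit.

Still open, from the compounds shown here alone, is whether any group on this shared core gives a measurable value in this assay.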